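This account rests on a few compounds, and the source may have more. Where it says the series, first, only, none or still open, it means among the compounds named here.

Of the compounds shown here, three built on one shared core have been tested in a functional assay on RAW264.7 cells (Mus musculus) for inhibition, read by microscopy and resazurin assay, with a stated time of 72 h; on this read-out higher numbers stand for weaker inhibition and lower numbers for stronger inhibition. Compound 1 `C=CCONC(=O)Cn1ccc(C(=O)N[C@@H](C)C(=O)N[C@H](C(=O)O)C(C)C)c1` opens the set; in this assay compound 1 gives > 128000 nM, which is a limit of the assay and not a number. Compound 2 `CC(C)[C@H](NC(=O)CNC(=O)c1ccn(CC(=O)NOCc2ccccc2)c1)C(=O)O` follows; in this assay compound 2 gives > 128000 nM, again a limit. Compound 3 `CC(C)C[C@H](NC(=O)CNC(=O)c1ccn(CC(=O)NOCc2ccccc2)c1)C(=O)O` closes the measured group; in this assay compound 3 gives > 128000 nM, also a limit. Among the measured compounds shown here, the one step between neighbours that differ in a single place, from compound 2 to compound 3, is a step that the two limits leave unreadable from compound 2 to compound 3, so neither its size nor its direction can be read. Where compound 2 stands is therefore known only as a limit, because the limit of > 128000 nM in this assay, at which 3 of the 3 values shown sit, and nothing shown separates compound 2 from its two companions.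

Compound 4 `CC(C)[C@H](NC(=O)[C@H](C)NC(=O)c1ccn(CC(=O)NOCc2ccccc2)c1)C(=O)O` differs from compound 2 by methyl in place of hydrogen on a saturated chain carbon bound to an amide-type nitrogen and a carbonyl carbon. For the measured compounds named here, the only measured step bearing on this change gives no readable size, so no direction in this assay can be drawn from it, and the set as a whole sits at the limit. Compound 4 is expected to give 200000 nM, within 60000 nM to 800000 nM, most probably reported once more as a limit. The expected step that the limit leaves unreadable from compound 2 to compound 4 stays within the scatter.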

Compound 4, half-maximal inhibitory concentration: > 128000 nM
Compound 4 gave a limit, no number; the forecaster's own chance of this, stated with the estimate: 85%; the middle value does not contradict the limit.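

Compound 4, like compound 1 and compound 2, gives a limit of the assay and not a number, so neither step to compound 4 can be read, because all the compounds share one limit: the limit of > 128000 nM in this assay, at which 4 of the 4 values shown sit.

The compounds shown leave open whether any change to the shared core would give a measurable number in this assay, and which change would do so.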